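Dimethylamino substitution on the pendant phenyl of the shared core

This account rests on a few compounds, and the source may have more. Where it says the series, first, only, none or still open, it means among the compounds named here.

Measured compounds in a functional assay on MCF7 cells (Homo sapiens) for inhibition, read by CCK-8 assay, with a stated time of 48 h; a lower number here means a stronger inhibitor, a higher number a weaker inhibitor:
compound 1 `COc1cc(-c2ccnc3cc(-c4ccc(C(C)(C)C)cc4)nn23)cc(OC)c1OC`, > 10000 nM
compound 2 `COc1cc(-c2ccnc3cc(-c4ccc(-c5cnn(C)c5)cc4)nn23)cc(OC)c1OC`, 274 nM
compound 3 `COc1cc(-c2ccnc3cc(-c4ccccc4)nn23)cc(OC)c1OC`, 254 nM

Compound 1 gives only a limit in this assay, as stated in the limit of > 10000 nM in this assay, at which 1 of the 3 values shown sits, and not a number. Compound 3 sits at the lowest of the two numbers, and compound 2 lies within the scatter of it, so nothing separates the two. Replacing the tert-butyl of compound 1 brings the large step of an at least 39-fold lower number from compound 1 to compound 3 (1.59 log units; beyond the scatter) and likewise an at least 36-fold lower number from compound 1 to compound 2 (1.56 log units; beyond the scatter), whereas the step of a 1.1-fold lower number from compound 2 to compound 3 (0.03 log units; within the scatter) shows no change beyond the scatter.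

Compound 4 `COc1cc(-c2ccnc3cc(-c4ccc(N(C)C)cc4)nn23)cc(OC)c1OC` is not yet measured. It differs from compound 3 by dimethylamino in place of hydrogen on an aromatic carbon. Going by the values given here, the steps that bear on it are a 1.1-fold lower number from compound 2 to compound 3 (0.03 log units; within the scatter), which shows that a substituent at this position can be carried without a change beyond the scatter, and an at least 39-fold lower number from compound 1 to compound 3 (1.59 log units; beyond the scatter), which shows that a tert-butyl there is not tolerated. Dimethylamino is a group of three heavy atoms with no ring, closer in size to neither extreme, so the expected step of a 1.6-fold higher number from compound 3 to compound 4 (0.20 log units; within the scatter) is small and within or near the scatter, with the risk of a weaker number. Compound 4 is thus expected at 400 nM, within 100 nM to 3000 nM.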

Compound 4, half-maximal inhibitory concentration: 44 nM
Beside the measured number, compound 4's estimate is 9.1-fold (0.96 log units) above it, outside the stated range (below it).
By their numbers in this assay, from the lowest: compound 4; then compounds 3 and 2 (each within the scatter of the next). At a limit, above all of these: compound 1.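

In this assay, going by these compounds alone, dimethylamino on the pendant phenyl gives the first change at this position that lowers the number beyond the scatter (a 5.8-fold lower number from compound 3 to compound 4 (0.76 log units; beyond the scatter)), where the earlier compounds showed only no change or a large loss. The same place therefore separates three outcomes among the groups shown: 1-methyl-1H-pyrazol-4-yl stays within the scatter of hydrogen, tert-butyl gives the highest reading, and dimethylamino stands clearly apart from the pyrazole as well (a 6.2-fold lower number from compound 2 to compound 4 (0.79 log units; beyond the scatter)), so what matters here is which group is carried and not merely whether one is. The widest span at this position (an at least 220-fold lower number from compound 1 to compound 4 (2.35 log units; beyond the scatter)) is a bound and not a measured size, as compound 1 gives a limit and not a number: the limit of > 10000 nM in this assay, at which 1 of the 4 values shown sits.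

On these data alone, whether the lower number belongs to dimethylamino as a whole or to its nitrogen alone stays open, and an unsubstituted amine, a methoxy group or a morpholine ring in the same place would begin to separate these readings. Whether the order of the compounds holds outside this assay also stays open, since every number shown comes from that single read-out.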